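This account rests on a few compounds, and the source may have more. Where it says the series, first, only, none or still open, it means among the compounds named here.

Measured in an assay on cells for inhibition of sodium- and chloride-dependent glycine transporter 1 (Homo sapiens); on this read-out higher numbers stand for an effect only at larger amounts of compound and lower numbers for an effect already at smaller amounts:
Compound 1 `COc1cc(C(F)(F)F)cc(SC)c1C(=O)NC1(c2ccc(Cl)cc2)CCCN(C)C1` gives 28 nM.
Compound 2 `COc1cc(C(F)(F)F)cc(SC)c1C(=O)NC1(c2cccnc2)CCCN(C)C1` gives 54 nM.
Compound 3 `COc1cc(C(F)(F)F)cc(SC)c1C(=O)NC1(c2ccncc2)CCCN(C)C1` gives 60 nM.

Among these three, compound 3 carries the highest number, but only a 2.1-fold higher number from compound 1 to compound 3 (0.33 log units; beyond the scatter) is beyond the scatter; a 1.1-fold higher number from compound 2 to compound 3 (0.05 log units; within the scatter) is within it, so compound 2 and compound 3 cannot be told apart.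

Compound 4 `COc1cc(C(F)(F)F)cc(SC)c1C(=O)NC1(c2ccncn2)CCCN(C)C1` differs from compound 3 by pyrimidin-4-yl in place of pyridin-4-yl on a saturated ring carbon. Among the compounds with values here, the steps that bear on this are the two exchanges of the 4-chlorophenyl group for a pyridyl group, a 1.9-fold higher number from compound 1 to compound 2 (0.29 log units; within the scatter) and a 2.1-fold higher number from compound 1 to compound 3 (0.33 log units; beyond the scatter), and the shift of the ring nitrogen, a 1.1-fold higher number from compound 2 to compound 3 (0.05 log units; within the scatter). Each change toward more ring nitrogen raised the number modestly or not at all. A second ring nitrogen is therefore expected to raise the number in this assay again, by a small amount that may stay within the scatter. Compound 4 is expected to give 90 nM, with a range from 40 nM to 250 nM. This estimate corresponds to an expected step of a 1.5-fold higher number from compound 3 to compound 4 (0.18 log units; within the scatter).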

Compound 4, half-maximal effective concentration: 1700 nM
Beside the measured number, compound 4's estimate is 19-fold (1.28 log units) below it, outside the stated range (above it).
By their numbers in this assay, from the lowest: compounds 1, 2 and 3 (each within the scatter of the next, the first and the last beyond it); then compound 4.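

In this assay, within the data shown here, the position on the saturated ring carbon proves far more sensitive than the earlier compounds suggested: pyrimidin-4-yl and pyridin-4-yl have the same number of heavy atoms and differ by one ring carbon exchanged for a nitrogen, yet this exchange gives a 28-fold higher number from compound 3 to compound 4 (1.45 log units; beyond the scatter). The other comparisons, a 31-fold higher number from compound 2 to compound 4 (1.50 log units; beyond the scatter) and a 61-fold higher number from compound 1 to compound 4 (1.78 log units; beyond the scatter), are also large, so compound 4 stands apart from a group whose numbers lie close together. Nothing available here accounts for this jump.

On these data alone, it remains open whether a pyrimidin-5-yl or pyrazin-2-yl group on this carbon would give a number like that of compound 4 or like that of compound 3. Also open, as far as these compounds go, is whether a methyl or amino group on the pyrimidin-4-yl ring would shift the number in either direction.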